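Urea series: heteroaryl swap on the benzyl arm

This account rests on a few compounds, and the source may have more. Where it says the series, first, only, none or still open, it means among the compounds named here.

Three ureas have been measured in an assay on microsomes from intestine for inhibition of acyl-CoA:cholesterol acyltransferase (Oryctolagus cuniculus); on this read-out lower numbers stand for stronger inhibition and higher numbers for weaker inhibition. Compound 1 `Cc1cc(C)c(NC(=O)N(Cc2ccc(-c3nnc(C)o3)cc2)C2CCCCCC2)c(C)c1` gives 27 nM; compound 2 `O=C(Nc1c(F)cc(F)cc1F)N(Cc1cccc(-c2cc[nH]n2)c1)C1CCCCCC1` gives 22 nM; compound 3 `CSc1cc(C)nc(SC)c1NC(=O)N(Cc1ccccc1)Cc1cccc(-c2ccnn2C)c1` gives 28 nM. Compound 1 stands second highest of the three, within the scatter of both compound 3 and compound 2. Compound 4 `Cc1cc(C)c(NC(=O)N(Cc2ccc(-c3ccnn3C)cc2)C2CCCCCC2)c(C)c1` is not yet measured and differs from compound 1 by 1-methyl-1H-pyrazol-5-yl in place of 5-methyl-1,3,4-oxadiazol-2-yl on an aromatic carbon, on an aromatic carbon of a six-membered aromatic ring of carbon only, para to a large group. Compound 3 carries the same 1-methyl-1H-pyrazol-5-yl on another core and gives 28 nM, within the scatter of compound 1. No step beyond the scatter is therefore expected, estimated as a 1.1-fold higher number from compound 1 to compound 4 (0.05 log units; within the scatter). Compound 4 is estimated at 30 nM, range 12 nM to 75 nM.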

Compound 4, half-maximal inhibitory concentration: 24 nM
Estimate against measurement, compound 4: 1.3-fold (0.10 log units) above; the range from low to high includes it.
By their numbers in this assay, from the lowest: compounds 2, 4, 1 and 3 (each within the scatter of the next).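

With the core of compound 1 held constant, 1-methyl-1H-pyrazol-5-yl in place of 5-methyl-1,3,4-oxadiazol-2-yl, para to a large group, gives a 1.1-fold lower number from compound 1 to compound 4 (0.05 log units; within the scatter) in this assay. Going by these compounds alone, this is the first matched pair at this position, and it shows that the two five-membered aromatic rings are interchangeable here within the scatter. No measurement available bears on why they read alike. As far as these compounds go, whether a morpholine or a carboxylic acid at this position would hold the number remains open. Also open, from the compounds shown here alone, is whether this swap reads the same on the cores of compound 2 and compound 3.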